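The source may report more compounds than this note shows. Statements on the series, on what has been measured and on what is new or still open speak of the compounds shown alone.

Within the data shown here, compound 2 `COc1ccc(-c2cc(-c3ccc(OC)cc3)c(C#N)c(SCC(=O)Nc3c(C)cccc3C)n2)cc1` is the only compound in this set with a reported number. In a functional assay on MG-63 cells (Homo sapiens) for inhibition, read by MTT assay, with a stated time of 72 h (a lower number here means that less compound is needed, a higher number that more compound is needed for the effect), compound 2 gives 35400 nM. A related compound, compound 1 `COc1ccc(-c2cc(-c3ccc(OC)cc3)c(C#N)c(SCC(=O)Nc3ccc(C)c(C)c3)n2)cc1`, was recorded in this assay as "not active" (no number reported), without a single number, so compound 2 cannot be ranked against it.

The next compound, compound 3 `CCc1ccccc1NC(=O)CSc1nc(-c2ccc(OC)cc2)cc(-c2ccc(OC)cc2)c1C#N`, keeps the shared core and differs from compound 2 only in one place: 2-ethylphenyl in place of 2,6-dimethylphenyl on an amide-type nitrogen. The two compounds contain the same atoms, joined differently.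

Among the measured compounds shown here, no step between measured compounds is available to guide this change. Since the rearrangement is small, the expected step in this assay is none beyond the usual scatter, with a slight lean toward a weaker result because compound 2 itself sits at 35400 nM. The expected step from compound 2 to compound 3 is a 1.3-fold higher number from compound 2 to compound 3 (0.10 log units; within the scatter). The estimate for compound 3 is 45000 nM, with a range from 15000 nM to 130000 nM.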

Compound 3, half-maximal effective concentration: 980 nM
Estimate against measurement, compound 3: 46-fold (1.66 log units) above, and the stated range ends above it.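

Replacing 2,6-dimethylphenyl with 2-ethylphenyl on the amide-type nitrogen gives a 36-fold lower number from compound 2 to compound 3 (1.56 log units; beyond the scatter) in this assay, so this position responds strongly to a change that keeps every atom. Both groups are carbon-only, with one six-membered aromatic ring and no net charge, which means that only the way those atoms are joined separates them. Nothing measured here explains why this rearrangement matters so much.

Among these compounds, compound 1 has no number, so no step involving it can be read. As far as these compounds go, it also remains open whether the gain would grow, hold or vanish with a longer chain, as in 2-propylphenyl, or with an amine or a carboxylic acid on this ring.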